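Ring size at the saturated carbon: compound 3 to compound 4

The source may hold more compounds than are shown below. What is called first, only, known or untested is meant among the compounds shown, and "the series" means these compounds.

Measured in a functional assay on the whole organism (plasma, strain Sprague-Dawley) with Rattus norvegicus as the target, with a stated time of 2 h, at a dose of 100 mg/kg by the oral route; a higher number here means a stronger effect of the compound at the dose given, a lower number a weaker effect:
- compound 1 `c1ccc(C(/N=C2\CCCCCCN2)C2CC2)cc1` gives 58%
- compound 2 `COc1ccc(C(/N=C2\CCCCCN2)C2CC2)cc1` gives 40%
- compound 3 `c1ccc(C(/N=C2\CCCCCN2)C2CCC2)cc1` gives 44%

Compound 3 stands second highest of the three numbers. Its nearest neighbour is compound 2, whose number is lower but within the scatter, so no order between compound 2 and compound 3 can be read. The furthest is compound 1, whose number is higher by a margin beyond the scatter; compound 1 also lies beyond the scatter above compound 2, so its number is the highest of the three. Within the data shown here, no pair of these three compounds differs in one place only, so no single step can be measured from them.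

Compound 4 `c1ccc(C(/N=C2\CCCCCN2)C2CCCCC2)cc1` differs from compound 3 in one place: cyclohexyl in place of cyclobutyl on a saturated chain carbon bound to an aromatic carbon and a double-bonded nitrogen. Among the measured compounds shown here, no measured pair shows what cyclohexyl in place of cyclobutyl at this position does, so the expectation for compound 4 in this assay rests on compound 3 alone. The step from compound 3 to compound 4 is expected to be small, a number 2 percentage points lower from compound 3 to compound 4 (within the scatter), not beyond the scatter in either direction. Compound 4 is estimated at 42%, with a range from 20% to 65%.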

Compound 4, a percentage reported as inhibition, in the whole organism at one dose (the size of the read-out at that dose, not a potency): 0%
Estimate against measurement, compound 4: 42 percentage points above, and the stated range ends above it.
By their numbers in this assay, from the lowest: compound 4; then compounds 2 and 3 (each within the scatter of the next); then compound 1.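

In this assay, among these compounds, the ring on the saturated chain carbon bound to an aromatic carbon and a double-bonded nitrogen matters a great deal: cyclohexyl in place of cyclobutyl gives a number 44 percentage points lower from compound 3 to compound 4 (beyond the scatter) and is the first single change that can be read. Compound 4 gives 0% at the dose used, so this position does not accept every ring of carbon only, even though both groups carry no hydrogen-bond donors or acceptors and no net charge. Nothing available explains the loss.

A cyclopentyl group at this position would show whether the read-out falls gradually or abruptly between the two rings. From the compounds shown here alone, whether the same loss appears with the other ring size in the core of compound 1, or with an isopropyl group, remains open.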